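Amide variation on a shared oxadiazole-azetidine core

The compounds below may be only part of what the source reports. "The series", "measured", "known", "first", "only" and "open" are said of these compounds alone.

Measured so far in an assay on HEK293 cells for negative allosteric modulation of metabotropic glutamate receptor 5 (Homo sapiens), read by FLIPR; on this read-out higher numbers stand for weaker inhibition and lower numbers for stronger inhibition:
- compound 1 `O=C(C1CCCCC1)N1CC(c2nc(-c3cccc(F)c3)no2)C1`: > 10000 nM
- compound 2 `O=C(c1ccc(F)c(F)c1)N1CC(c2nc(-c3cccc(F)c3)no2)C1`: > 10000 nM
- compound 3 `Cc1ccc(C(=O)N2CC(c3nc(-c4cccc(F)c4)no3)C2)cc1`: > 10000 nM

The value of compound 1 in this assay is a limit of the assay, not a number. The same holds for compound 2, whose result in this assay is likewise a limit. Compound 3 too gives only a limit in this assay. Accordingly the limit of > 10000 nM in this assay, at which 3 of the 3 values shown sit: every one of the three values sits at that limit, and compound 3 cannot be ranked against either neighbour.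

Compound 4 `O=C(c1ccc(F)cc1)N1CC(c2nc(-c3cccc(F)c3)no2)C1` remains to be measured. It differs from compound 3 by fluoro in place of methyl on an aromatic carbon, the fluoro entering on an aromatic carbon of a six-membered aromatic ring of carbon only.

For the measured compounds named here, the steps that bear on it are a step that the two limits leave unreadable from compound 1 to compound 3 and a step that the two limits leave unreadable from compound 2 to compound 3, and likewise a step that the two limits leave unreadable from compound 1 to compound 2; none is readable in size, since both ends of each are limits. Changes at the carbonyl substituent have thus shown no measurable gain anywhere in the series.

Compound 4 is therefore expected to stay at or near the limit, an estimate of 15000 nM (range 5000 nM to 50000 nM), meaning an expected step that the limit leaves unreadable from compound 3 to compound 4 within scatter.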

Compound 4, half-maximal inhibitory concentration: > 10000 nM
Compound 4: no number, only a limit; the forecaster's own chance of this, stated with the estimate: 85%; the middle value does not contradict the limit.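

In this assay compound 4 gives > 10000 nM, which is a limit of the assay and not a number. None of the steps to compound 4 from compound 1, compound 2 or compound 3 can be read. The compounds shown leave open which carbonyl substituent on the shared core, if any, gives a measurable value: the limit of > 10000 nM in this assay, at which 4 of the 4 values shown sit.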